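Chloro for Fluoro in Macrophage Cytotoxicity

A few compounds are considered here, and "the series" means these few. Any claim that something is new, unique, unknown or untested is made for them only; others in the source may bear on it.

Compound 2 `O=c1oc2ccccc2c(=O)n1-c1ccc(F)cc1F` and compound 1 `O=c1oc2ccccc2c(=O)n1-c1ccc(Cl)cc1F` share one core. In an ADME assay on RAW264.7 cells (Mus musculus) for cytotoxicity, read by MTT assay, with a stated time of 24 h (a higher number here means that more compound is tolerated, a lower number that less compound is tolerated), compound 2 reaches only a limit, > 40000 nM. In this assay compound 1 gives 26500 nM. The change between them is chloro in place of fluoro on an aromatic carbon, and the step is an at least 1.5-fold lower number from compound 2 to compound 1 (0.17 log units; that floor lies within the scatter). Compound 3 `O=C(Nc1ccc(-c2ccc(Cl)cc2F)cc1F)c1ccccc1O` rests on another core; the difference between the two cores is not broken down here. In this assay compound 3 gives 27200 nM, a value within the scatter of that of compound 1. Compound 4 `O=C(Nc1ccc(-c2ccc(Cl)cc2Cl)cc1F)c1ccccc1O` is not yet measured; from compound 3 it differs by chloro in place of fluoro on an aromatic carbon. This is the same kind of change as from compound 2 to compound 1, though the place differs: here ortho to a large group and meta to a chloro group, there meta to a fluoro group and para to a large group. Resting on an at least 1.5-fold lower number from compound 2 to compound 1 (0.17 log units; that floor lies within the scatter), compound 4 is expected to show a 1.4-fold lower number from compound 3 to compound 4 (0.13 log units; within the scatter), with an estimated 20000 nM (10000 nM to 40000 nM).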

Compound 4, half-maximal cytotoxic concentration: 29800 nM
Compound 4: the middle estimate sits 1.5-fold (0.17 log units) below what was measured, and the stated range covers the measured number.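

In this assay the change of chloro for fluoro on the second core gives a 1.1-fold higher number from compound 3 to compound 4 (0.04 log units; within the scatter), so on that core the step stays within the scatter. Set beside the earlier step, this does not separate the two cores: the same change on two cores in this assay, an at least 1.5-fold lower number (0.17 log units; that floor lies within the scatter) from compound 2 to compound 1 and a 1.1-fold higher number (0.04 log units; within the scatter) from compound 3 to compound 4; the limit leaves it open whether they differ. Compound 2 gives only a limit, so the earlier step has no exact size, and the result shows neither that the change carries across the cores nor that it does not: the limit of > 40000 nM in this assay, at which 1 of the 4 values shown sits.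

The compounds shown leave open what a bromo or a methoxy group in that place would do in this assay. They also leave open how the change would read on a core carrying an amine or a carboxylic acid.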